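Ester chain variation and cytotoxicity in the series

A few compounds are considered here, and "the series" means these few. Any claim that something is new, unique, unknown or untested is made for them only; others in the source may bear on it.

Measured in a functional assay on PRK cells (Oryctolagus cuniculus) for cytotoxicity; on this read-out higher numbers stand for lower toxicity in this test and lower numbers for higher toxicity in this test:
compound 1 `CCCCCCCCOC(=O)C(O)Cn1cnc2c(N)ncnc21`: 100 ug/mL
compound 2 `CC(C)OC(=O)C(O)Cn1cnc2c(N)ncnc21`: > 400 ug/mL, a limit of this assay
compound 3 `COCCOC(=O)C(O)Cn1cnc2c(N)ncnc21`: > 400 ug/mL, a limit of this assay

Compound 3 gives only a limit of this assay and no number of its own (the limit of > 400 ug/mL in this assay, at which 2 of the 3 values shown sit). Compound 4 `CCCCCOC(=O)C(O)Cn1cnc2c(N)ncnc21` differs from compound 3 by propyl in place of methoxy on a saturated chain carbon, two bonds along the chain from an oxygen next to a carbonyl group. For the measured compounds named here, the steps that bear on this change run the other way: an at least 4.0-fold higher number from compound 1 to compound 3 (0.60 log units; beyond the scatter) and an at least 4.0-fold higher number from compound 1 to compound 2 (0.60 log units; beyond the scatter), while a step that the two limits leave unreadable from compound 2 to compound 3. Propyl is shorter than the hexyl carried by compound 1 at this place, so compound 4 is expected to land between compound 1 and the limit, a modest lowering in this assay, an at least 1.6-fold lower number from compound 3 to compound 4 (0.20 log units; that floor lies within the scatter). Compound 4 is estimated at 250 ug/mL, expected within 100 ug/mL to 400 ug/mL.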

Compound 4, minimum cytotoxic concentration: 200 ug/mL
The estimate for compound 4 lay 1.3-fold (0.10 log units) above the measured number; the range from low to high includes it.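

In this assay, propyl in place of methoxy on a saturated chain carbon gives an at least 2.0-fold lower number from compound 3 to compound 4 (0.30 log units; that floor lies within the scatter), and pentyl in place of isopropyl gives an at least 2.0-fold lower number from compound 2 to compound 4 (0.30 log units; that floor lies within the scatter). Both steps now end on a number, though each floor lies within the scatter. The pentyl and octyl esters are not told apart, with a 2.0-fold higher number from compound 1 to compound 4 (0.30 log units; within the scatter).

On these data alone, the size of both steps stays unknown, as compound 2 and compound 3 give only limits: the limit of > 400 ug/mL in this assay, at which 2 of the 4 values shown sit. Where a butyl ester, a chain longer than octyl or an amine at the chain end would fall stays open.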